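A linker change from compound 2 to compound 4

The source may report more compounds than this note shows. Statements on the series, on what has been measured and on what is new or still open speak of the compounds shown alone.

Three measured compounds share one core and differ only in the ring carried on the side chain. In a functional assay on HCT-116 cells (Homo sapiens) for inhibition, read by sulforhodamine B assay, with a stated time of 48 h (on this read-out higher numbers stand for weaker inhibition of growth and lower numbers for stronger inhibition of growth), compound 1 `Nc1cc(N)c2nc(-c3ccccc3)c(NCc3ccc(Cl)c(Cl)c3)nc2c1` gives 11500 nM, compound 2 `Nc1cc(N)c2nc(-c3ccccc3)c(NCc3ccc(F)cc3)nc2c1` gives 12900 nM, and compound 3 `COc1ccc(CNc2nc3cc(N)cc(N)c3nc2-c2ccccc2)cc1` gives 14500 nM. The steps of a 1.1-fold higher number from compound 1 to compound 2 (0.05 log units; within the scatter), a 1.3-fold higher number from compound 1 to compound 3 (0.10 log units; within the scatter) and a 1.1-fold higher number from compound 2 to compound 3 (0.05 log units; within the scatter) all lie within the scatter, so compound 2 sits among three numbers that cannot be told apart. Compound 4 `Nc1cc(N)c2nc(-c3ccccc3)c(Sc3ccc(F)cc3)nc2c1` differs in another way: (4-fluorophenyl)sulfanyl in place of (4-fluorobenzyl)amino on an aromatic carbon. For the measured compounds named here, no measured step touches this kind of change, so the measured steps give no direction for it. The expected step of a 1.2-fold higher number from compound 2 to compound 4 (0.09 log units; within the scatter) is therefore set close to zero with a wide margin. Compound 4 is expected to give 16000 nM in this assay, with a range from 5000 nM to 50000 nM.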

Compound 4, concentration for 50% growth inhibition: 14800 nM
For compound 4 the middle estimate is 1.1-fold (0.03 log units) above the measured one, within the range that was stated.
By their numbers in this assay, from the lowest: compounds 1, 2, 3 and 4 (each within the scatter of the next).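

In this assay the swap of (4-fluorobenzyl)amino for (4-fluorophenyl)sulfanyl gives a 1.1-fold higher number from compound 2 to compound 4 (0.06 log units; within the scatter) on the shared core. The earlier compounds shown here changed only the ring on the side chain, whereas here the link to the core changes too: the hydrogen-bond donor of the leaving group is gone and a sulfur joins the ring, yet the number stays within the scatter. Nothing available explains this result. Still open, going by these compounds, is whether a longer chain between core and ring, or an amine or carboxylic acid on that ring, would shift the number beyond the scatter.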